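Cytotoxicity notes on a chalcone-pyrazole series

A few compounds are considered here, and "the series" means these few. Any claim that something is new, unique, unknown or untested is made for them only; others in the source may bear on it.

Measured compounds:
compound 1 `COc1cc(-c2cc(/C=C/C(=O)c3ccc(N)cc3)[nH]n2)cc(OC)c1OC`: -69%
compound 2 `COc1ccc(-c2cc(/C=C/C(=O)c3ccc(N)cc3)[nH]n2)cc1`: -89%

In a functional assay on UACC-62 cells (Homo sapiens) for cytotoxicity, read by sulforhodamine B assay, with a stated time of 48 h, tested at 10 uM (a higher number here means a weaker effect of the compound at the concentration tested, a lower number a stronger effect), compound 1 gives -69% and compound 2 gives -89%. Of the two numbers, compound 1 stands highest; its nearest neighbour is compound 2, which lies lower by a gap beyond the usual scatter, so compound 1 is the weaker of the pair at the concentration tested. The two compounds differ in more than one place, so nothing is drawn from that gap beyond what the two values show.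

Compound 3 `COc1ccc(C(=O)/C=C/c2cc(-c3cc(OC)c(OC)c(OC)c3)n[nH]2)cc1OC` has not been measured in this assay. It differs from compound 1 in one place: 3,4-dimethoxyphenyl in place of 4-aminophenyl on a carbonyl carbon. For the measured compounds named here, no step of this kind between measured compounds is available, so there is no basis for expecting a shift beyond the scatter in either direction. The step from compound 1 to compound 3 is therefore expected to be about a number 4 percentage points higher from compound 1 to compound 3 (within the scatter). For compound 3 an activity near -65% is estimated, within a range from -92% to -35%.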

Compound 3, a percentage reported as activity, at one concentration (the size of the read-out at that concentration, not a potency): -92%
For compound 3 the middle estimate is 27 percentage points above the measured one; measured number inside the range.
By their numbers in this assay, from the lowest: compounds 3 and 2 (each within the scatter of the next); then compound 1.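

On the carbonyl carbon, the 4-aminophenyl group is not needed for the effect in this assay: 3,4-dimethoxyphenyl in its place gives a number 23 percentage points lower from compound 1 to compound 3 (beyond the scatter), a reading of this position that the earlier pair, differing in more than one place, could not give. The entering group counts 0 hydrogen-bond donors against 1 on the leaving group, so within this pair a donor on this phenyl group is not required for the stronger effect. Nothing at hand bears on why the step occurs.

Still open, on these data alone, is whether a single methoxy group, a hydroxyl or a chlorine on this phenyl ring would give a similar step. As far as these compounds go, it is also open whether the step carries over when 3,4-dimethoxyphenyl enters the core of compound 2.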